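Swapping Bromo for Chloro on a Shared Core

The source may report more compounds than this note shows. Statements on the series, on what has been measured and on what is new or still open speak of the compounds shown alone.

Of the compounds shown here, three built on one shared core have been tested in a functional assay on A-375 cells (Homo sapiens) for antiproliferative activity, read by MTT assay, with a stated time of 48 h; on this read-out higher numbers stand for weaker inhibition and lower numbers for stronger inhibition. Compound 1, `O=C(Nc1cc(-c2ccccc2)[nH]n1)c1ccc(Br)nc1`, gives 8870 nM. Compound 2, `O=C(Nc1cc(-c2ccccc2)[nH]n1)c1ccc(Cl)nc1`, differs from compound 1 by chloro in place of bromo on an aromatic carbon. In this assay compound 2 gives 7850 nM, a step of a 1.1-fold lower number from compound 1 to compound 2 (0.05 log units; within the scatter). Compound 3, `O=C(Nc1cc(-c2ccc(Br)cc2)[nH]n1)c1ccc(Br)nc1`, differs from compound 1 by bromo in place of hydrogen on an aromatic carbon. In this assay compound 3 gives 9910 nM, a step of a 1.1-fold higher number from compound 1 to compound 3 (0.05 log units; within the scatter). These three numbers sit close together, so none of the compounds can be called stronger or weaker than another.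

Compound 4, `O=C(Nc1cc(-c2ccc(Br)cc2)[nH]n1)c1ccc(Cl)nc1`, has not yet been measured. It differs from compound 3 by chloro in place of bromo on an aromatic carbon, and the surroundings of that change are the same as in the swap that turned compound 1 into compound 2. Because a 1.1-fold lower number from compound 1 to compound 2 (0.05 log units; within the scatter) was a small step, the expected step is a 1.1-fold lower number from compound 3 to compound 4 (0.05 log units; within the scatter). Given that compound 3 gives 9910 nM, compound 4 is expected to give about 8800 nM in this assay, most likely falling between 4500 nM and 18000 nM.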

Compound 4, half-maximal inhibitory concentration: 8890 nM
Compound 4: the middle estimate sits 1.0-fold (0.00 log units) below what was measured, and the stated range covers the measured number.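

In this assay, chloro in place of bromo now reads as a 1.1-fold lower number from compound 3 to compound 4 (0.05 log units; within the scatter), and this step matches the earlier swap: the same change on two cores in this assay, a 1.1-fold lower number (0.05 log units; within the scatter) from compound 1 to compound 2 and a 1.1-fold lower number (0.05 log units; within the scatter) from compound 3 to compound 4, 1.0-fold (0.01 log units) apart, within the scatter of two such steps

Bromo in place of hydrogen reads as a 1.1-fold higher number from compound 2 to compound 4 (0.05 log units; within the scatter), and this step also matches its earlier counterpart: the same change on two cores in this assay, a 1.1-fold higher number (0.05 log units; within the scatter) from compound 1 to compound 3 and a 1.1-fold higher number (0.05 log units; within the scatter) from compound 2 to compound 4, 1.0-fold (0.01 log units) apart, within the scatter of two such steps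

So on these two cores each change gave much the same step, but every step lies within the scatter, which means this agreement shows only that neither change produced a measurable difference on either core, not that a change with a real effect would carry over in the same way.

The compounds shown carry only bromo, chloro or hydrogen at the two places that vary, so they leave open what a quite different group there, such as an amine, a carboxylic acid or a longer chain, would do to the number. They also leave open whether any step that lies beyond the scatter would repeat from one core to the other.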